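The compounds below may be only part of what the source reports. "The series", "measured", "known", "first", "only" and "open" are said of these compounds alone.

Compound 1 `CCCCCCCCCCc1cc2cn([C@H]3C[C@H](O)[C@@H](CO)O3)c(=O)nc2o1`. In an ADME assay on HEL cells (Homo sapiens) for cytotoxicity, with a stated time of 3 days (a higher number here means that more compound is tolerated, a lower number that less compound is tolerated), compound 1 gives > 510000 nM, a limit of the assay. Compound 2 `O=c1nc2oc(CCc3ccccc3)cc2cn1[C@H]1C[C@H](O)[C@@H](CO)O1`. In this assay compound 2 gives > 560000 nM, again a limit of the assay. Compound 3 `CCCCCc1ccc(C#Cc2cc3cn([C@H]4C[C@H](O)[C@@H](CO)O4)c(=O)nc3o2)cc1`. In this assay compound 3 gives 110000 nM.

Compound 3 is therefore the only one of the three with an actual number; the other two are limits. For the measured compounds named here, the single measured step, a step that the two limits leave unreadable from compound 1 to compound 2, cannot be read and does not touch the change considered here. Compound 4 `Cc1ccc(C#Cc2cc3cn([C@H]4C[C@H](O)[C@@H](CO)O4)c(=O)nc3o2)cc1` differs from compound 3 by hydrogen in place of butyl on a saturated chain carbon bound to an aromatic carbon. Going by the values given here, no measured step bears on shortening the chain in this way, so the expectation rests on compound 3 at 110000 nM alone. Compound 4 is expected to give 250000 nM in this assay, within 90000 nM to 600000 nM. That estimate means an expected step of a 2.3-fold higher number from compound 3 to compound 4 (0.36 log units; beyond the scatter).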

Compound 4, half-maximal cytotoxic concentration: 510000 nM
The estimate for compound 4 lay 2.0-fold (0.31 log units) below the measured number; low and high end bracket the measured number.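

In this assay, for the compounds shown here, the change from pentyl to methyl gives a 4.6-fold higher number from compound 3 to compound 4 (0.67 log units; beyond the scatter), the first readable step here, so the length of this chain does matter for how much compound the cells tolerate. Exchanging phenethyl for 2-(4-methylphenyl)ethynyl gives an at least 1.0-fold lower number from compound 2 to compound 4 (0.04 log units; that floor lies within the scatter), a floor within the scatter, which sets no order between the two groups. Compound 2 stands only as a limit: the limit of > 560000 nM in this assay, at which 1 of the 4 values shown sits.

Going by these compounds, with just pentyl and methyl at this place, the course of the effect between them remains open. On these data alone, whether an ethyl or propyl chain falls in between, and how an amine or a carboxylic acid at the chain end would behave, also remains unknown.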